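A few compounds are considered here, and "the series" means these few. Any claim that something is new, unique, unknown or untested is made for them only; others in the source may bear on it.

Compound 1 `COc1ccccc1/C=C1/C(C)=C(CC(=O)O)c2cc(F)ccc21` carries a 2-methoxyphenyl group on the double-bonded chain carbon that is bound to a double-bonded ring carbon of its core. In a functional assay on REF cells (Rattus norvegicus) for antiproliferative activity (a higher number here means a weaker inhibitor, a lower number a stronger inhibitor), compound 1 gives 200000 nM, which places it at the weak end of what has been measured in this series. Compound 2 `CC1=C(CC(=O)O)c2cc(F)ccc2/C1=C\c1ccc(C)o1`, which carries a 5-methylfuran-2-yl group at the same place, has been measured more than once in this assay; compound 2 gives 20000 nM; 10000 nM (2 entries), and the spread among those repeats is seen in the several entries of compound 2 in this assay, 20000 nM; 10000 nM (2 entries). The two compounds differ in more than one respect, so their values can only be set side by side.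

Compound 3 `CC1=C(CC(=O)O)c2cc(F)ccc2/C1=C\c1cccs1` is not yet measured. It comes from compound 1 by thiophen-2-yl in place of 2-methoxyphenyl on a double-bonded chain carbon bound to a double-bonded ring carbon. Since compound 2, the other compound with a five-membered aromatic ring at this place, sits well below compound 1, the step from compound 1 to compound 3 is expected to be a clear gain in inhibition, beyond the usual scatter: a 10-fold lower number from compound 1 to compound 3 (1.00 log units; beyond the scatter). Compound 3 is therefore estimated at 20000 nM in this assay, with a likely range from 5000 nM to 80000 nM.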

Compound 3, half-maximal inhibitory concentration: 100000 nM
For compound 3 the middle estimate is 5.0-fold (0.70 log units) below the measured one; the measured number lies above the stated range.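

Replacing 2-methoxyphenyl with thiophen-2-yl on a double-bonded chain carbon bound to a double-bonded ring carbon gives a 2.0-fold lower number from compound 1 to compound 3 (0.30 log units; within the scatter) in this assay, so this swap of a six-membered aromatic ring for a five-membered one does not clearly separate the two compounds. A five-membered aromatic ring at this place is therefore not enough on its own to bring a number like that of compound 2, 20000 nM; 10000 nM (2 entries), and the idea that ring size alone sets the value finds no support in compound 3. A step of this size also has to be read against how far repeat measurements in this series can differ: the several entries of compound 2 in this assay, 20000 nM; 10000 nM (2 entries)

On these data alone, it remains open how a plain furan-2-yl or a 5-methylthiophen-2-yl group would read at this place, and so whether the value of compound 2 goes with the oxygen of its ring, with its methyl group or with both together. Also open, as far as these compounds go, is what an aromatic ring carrying an amine would give on the same carbon of the shared core.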